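The compounds below may be only part of what the source reports. "The series", "measured", "known", "first", "only" and "open" are said of these compounds alone.

Compound 1 `CCC[C@@H](CCO)Nc1nc(N)nc(C)c1Cc1ccc(CNC)cc1OC` gives 6460 nM in an assay on HEK293 cells for agonist activity at Toll-like receptor 8 (Homo sapiens); a lower number here means that less compound is needed, a higher number that more compound is needed for the effect. Compound 2 `CCC[C@@H](CO)Nc1nc(N)nc(C)c1Cc1ccc(CN(C)C)cc1OC` carries a dimethylamino-bearing side chain and a shorter hydroxyalkyl group and gives 490 nM in this assay. Compound 3 `CCC[C@@H](CCO)Nc1nc(N)nc(C)c1Cc1ccc(CNCC(N)=O)cc1OC` reaches only the limit of this assay, > 10000 nM, so no number is known for it. Among the compounds with values here, the one step that can be read, an at least 1.5-fold higher number from compound 1 to compound 3 (0.18 log units; that floor lies within the scatter), leaves the size of that loss open, since the measurement stops at the limit (the limit of > 10000 nM in this assay, at which 1 of the 3 values shown sits). Compound 4 `CCC[C@@H](CCO)Nc1nc(N)nc(C)c1Cc1ccc(Cn2ccnc2)cc1OC` differs from compound 3 in one place: 1H-imidazol-1-yl in place of (carbamoylmethyl)amino on a saturated chain carbon bound to an aromatic carbon. Within the data shown here, no measured step on this scaffold shows an aromatic ring at that position, so the change is judged only against the weak starting point of compound 3 and the single step from compound 1. Compound 4 is expected to sit near the level of compound 1, with an estimated step of an at least 2.0-fold lower number from compound 3 to compound 4 (0.30 log units; that floor lies within the scatter). The estimate for compound 4 in this assay is 5000 nM, within a range from 1000 nM to 20000 nM.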

Compound 4, half-maximal effective concentration: 4900 nM
Compound 4: middle estimate off by 1.0-fold (0.01 log units), on the high side; measured number inside the range.
By their numbers in this assay, from the lowest: compound 2; then compounds 4 and 1 (each within the scatter of the next). At a limit, above all of these: compound 3.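

Within the data shown here, with 1H-imidazol-1-yl in place of methylamino there is a 1.3-fold lower number from compound 1 to compound 4 (0.12 log units; within the scatter), so on a saturated chain carbon bound to an aromatic carbon, a place that had so far held only open-chain amino groups, a five-membered aromatic ring with 0 hydrogen-bond donors gives a number level with that of methylamino in this assay. As far as these compounds go, measured against (carbamoylmethyl)amino, the same ring gives an at least 2.0-fold lower number from compound 3 to compound 4 (0.30 log units; that floor lies within the scatter), and the true size of this step stays unknown. Compound 3 stands at a limit and has no number: the limit of > 10000 nM in this assay, at which 1 of the 4 values shown sits.

From the compounds shown here alone, whether another ring at this place, such as 1H-pyrazol-1-yl or morpholin-4-yl, would give a different number remains open. So does the effect of dimethylamino alone, since compound 2 also carries the shorter hydroxyalkyl group and differs from the others in more than one place.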